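From methylsulfonyl to cyclopropylsulfonyl on a ring nitrogen

The source may hold more compounds than are shown below. What is called first, only, known or untested is meant among the compounds shown, and "the series" means these compounds.

In a functional assay on MDA-MB-231 cells (Homo sapiens) for inhibition, read by sulforhodamine B assay, tested at 10 uM (on this read-out higher numbers stand for more inhibition at the one concentration tested (going by the name of the read-out) and lower numbers for less inhibition), compound 1 `CN1CCN(c2ccc(C3=NNC(c4ccc(N(C)C)cc4)C3)cc2)CC1` gives 11.4%, compound 2 `CN1CCN(c2ccc(C3=NN(C(=O)CCCl)C(c4ccc(N(C)C)cc4)C3)cc2)CC1` gives 2.4%, and compound 3 `CN1CCN(c2ccc(C3=NN(S(C)(=O)=O)C(c4ccc(N(C)C)cc4)C3)cc2)CC1` gives 0.6%, the lowest of the three numbers. The step of a number 10.8 percentage points lower from compound 1 to compound 3 (beyond the scatter) lies beyond the scatter, whereas a number 9 percentage points lower from compound 1 to compound 2 (within the scatter) and a number 1.8 percentage points lower from compound 2 to compound 3 (within the scatter) do not, so compound 3 and compound 2 cannot be told apart on these numbers, and all three compounds sit in the low part of the scale. Compound 4 `CN1CCN(c2ccc(C3=NN(S(=O)(=O)C4CC4)C(c4ccc(N(C)C)cc4)C3)cc2)CC1` differs from compound 3 in one place: cyclopropyl in place of methyl on a sulfonyl sulfur. For the measured compounds named here, none of the measured steps alters the group on the sulfonyl sulfur; the closest precedents are a number 10.8 percentage points lower from compound 1 to compound 3 (beyond the scatter) and a number 1.8 percentage points lower from compound 2 to compound 3 (within the scatter), which show that putting a group on an amine nitrogen in a ring has so far left the inhibition near the bottom of the scale. For the step to compound 4 a change within the scatter is therefore expected, a number 2.4 percentage points higher from compound 3 to compound 4 (within the scatter). Compound 4 is accordingly estimated at 3%, with a range from -6% to 14%.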

Compound 4, a percentage reported as inhibition, at one concentration (the size of the read-out at that concentration, not a potency): 3.7%
Compound 4: middle estimate off by 0.7 percentage points, on the low side, within the range that was stated.
By their numbers in this assay, from the lowest: compounds 3, 2, 4 and 1 (each within the scatter of the next, the first and the last beyond it).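

Cyclopropyl in place of methyl on a sulfonyl sulfur is the first change shown at this place, and in this assay the larger group with its three-membered ring gives a step that cannot be told from scatter (a number 3.1 percentage points higher from compound 3 to compound 4 (within the scatter)). The cyclopropylsulfonyl group also cannot be separated from the (2-chloroethyl)carbonyl group (a number 1.3 percentage points higher from compound 2 to compound 4 (within the scatter)) or from hydrogen on the same ring nitrogen (a number 7.7 percentage points lower from compound 1 to compound 4 (within the scatter)), so only the methylsulfonyl compound stands beyond the scatter from compound 1. No measurement is available that would explain these numbers.

Still open, on these data alone, is whether a phenyl ring or a longer alkyl chain on the sulfonyl sulfur would move the inhibition further from the bottom of the scale. An amine-bearing chain on the same ring nitrogen also remains an untested question in the compounds shown here.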